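A few compounds are considered here, and "the series" means these few. Any claim that something is new, unique, unknown or untested is made for them only; others in the source may bear on it.

Compound 2 `COc1ccc2c(C3(c4c[nH]c5cc(OC)ccc45)C(=O)Nc4ccccc43)c[nH]c2c1` carries two methoxy indoles on the shared core. In a functional assay on MCF7 cells (Homo sapiens) for cytotoxicity, read by MTT assay, with a stated time of 48 h (a higher number here means a weaker inhibitor, a lower number a stronger inhibitor), compound 2 gives 45400 nM, the largest of the three numbers shown; the gap to compound 1 `COc1cccc2[nH]cc(C3(c4c[nH]c5cccc(OC)c45)C(=O)Nc4ccccc43)c12`, which gives 14100 nM, lies beyond the scatter, while compound 3 `O=C1Nc2ccc(F)cc2C1(c1c[nH]c2ccccc12)c1c[nH]c2ccccc12`, which gives 23600 nM, sits within the scatter of compound 2. Compound 4 `COc1ccc2c(C3(c4c[nH]c5cc(OC)ccc45)C(=O)Nc4ccc(F)cc43)c[nH]c2c1` differs from compound 2 by fluoro in place of hydrogen on an aromatic carbon. Going by the values given here, no measured pair isolates this change, and compound 3 differs from the others in more than one place, so nothing here fixes the size of the step. The expectation is a step from compound 2 to compound 4 of no more than the scatter, a 1.3-fold lower number from compound 2 to compound 4 (0.11 log units; within the scatter), in this assay. Compound 4 is therefore estimated at 35000 nM, within 12000 nM to 100000 nM.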

Compound 4, half-maximal inhibitory concentration: 12000 nM
Beside the measured number, compound 4's estimate is 2.9-fold (0.46 log units) above it; measured number inside the range.
By their numbers in this assay, from the lowest: compounds 4, 1, 3 and 2 (each within the scatter of the next, the first and the last beyond it).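

Going by these compounds alone, the pair compound 2 and compound 4 is the first to isolate a single change: in this assay, fluoro in place of hydrogen on this aromatic carbon gives a 3.8-fold lower number from compound 2 to compound 4 (0.58 log units; beyond the scatter), so the step is modest but not lost in the scatter. The position therefore responds to a single fluorine atom on the dimethoxy scaffold of compound 2. No evidence on hand accounts for the step.

From the compounds shown here alone, whether chloro, nitrile or an amine on the same carbon would move the number likewise remains open. So does whether the fluoro step carries over to the methoxy placement of compound 1.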